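Sulfamoyl on the N-phenyl of a dihydroxyphenyl pyrazole

The compounds below may be only part of what the source reports. "The series", "measured", "known", "first", "only" and "open" are said of these compounds alone.

Measured compounds in a functional assay on cells (Cancer cell lines, Homo sapiens) for cytotoxicity, read by sulforhodamine B assay, with a stated time of 48 h; a lower number here means a stronger inhibitor of growth, a higher number a weaker inhibitor of growth:
compound 1 `COc1ccc(OC)c(-c2cc(-c3ccccc3)nn2-c2ccc(S(N)(=O)=O)cc2)c1` gives 13900 nM
compound 2 `Oc1ccc(O)c(-c2cc(-c3ccccc3)nn2-c2ccccc2)c1` gives 16700 nM
compound 3 `Oc1ccc(O)c(-c2cc(-c3ccc(Cl)cc3)nn2-c2ccccc2)c1` gives 14600 nM

Compound 2 carries the highest number of the three, but its distance to the others is small: compound 3 sits a 1.1-fold lower number from compound 2 to compound 3 (0.06 log units; within the scatter), and compound 1, the furthest, lies only a little lower still, with both gaps within the scatter. So far nothing in the series separates the compounds beyond repeat variation.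

Compound 4 `NS(=O)(=O)c1ccc(-n2nc(-c3ccccc3)cc2-c2cc(O)ccc2O)cc1` is compound 2 with sulfamoyl in place of hydrogen on an aromatic carbon. Among the measured compounds shown here, no measured pair isolates this change. Compound 1, which also carries a sulfamoyl, differs from compound 2 in the two methoxy groups as well, so its value can only be read alongside that of compound 2, where the two sit within the scatter of each other. For the measured compounds named here, the only single-point step known, from compound 2 to compound 3, is within the scatter and concerns a different position.

On this basis no movement beyond the scatter is expected in this assay for compound 4, and the step from compound 2 to compound 4 is estimated at a 1.2-fold lower number from compound 2 to compound 4 (0.08 log units; within the scatter). Compound 4 is expected to give about 14000 nM, with a range from 6000 nM to 35000 nM.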

Compound 4, concentration for 50% growth inhibition: 77600 nM
For compound 4 the middle estimate is 5.5-fold (0.74 log units) below the measured one; the measured number lies above the stated range.
By their numbers in this assay, from the lowest: compounds 1, 3 and 2 (each within the scatter of the next); then compound 4.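

In this assay, among the compounds shown here, sulfamoyl in place of hydrogen on an aromatic carbon, para to a large group, gives a 4.6-fold higher number from compound 2 to compound 4 (0.67 log units; beyond the scatter) and so becomes the first single-place change to move the number beyond the scatter. The earlier chloro step gave no such movement, so this position or this group responds in a way the first three compounds did not reveal. With the sulfamoyl held constant, 2,5-dihydroxyphenyl in place of 2,5-dimethoxyphenyl gives a 5.6-fold higher number from compound 1 to compound 4 (0.75 log units; beyond the scatter), which shows that the outcome of carrying a sulfamoyl depends on the group at the other aromatic position, and no measurement at hand accounts for either step.

The compounds shown leave open whether the higher number belongs to sulfamoyl in particular or would also follow from another group at the same place, such as a carboxylic acid, an amine or a methyl ether. They also leave open how the 2,5-dimethoxyphenyl compound behaves without the sulfamoyl, so the size of the sulfamoyl step on that background cannot yet be read.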